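Pyrrolidin-1-yl to piperidin-1-yl on a carbonyl carbon

This account rests on a few compounds, and the source may have more. Where it says the series, first, only, none or still open, it means among the compounds named here.

Measured so far in a physicochemical assay for acid dissociation, as follows

- compound 1 `CC(C)n1cc(-c2ccnc3[nH]c(C4CCN(CC(=O)N5CCCC5)CC4)cc23)ccc1=O` gives 7.8
- compound 2 `CC(C)n1nc(-c2ccnc3[nH]c(C4CCN(CC(=O)N(C)C)CC4)cc23)ccc1=O` gives 7.6

In this assay compound 1 at 7.8 and compound 2 at 7.6 lie within the scatter of each other, so neither stands apart on these two numbers. Within the data shown here, no measured pair differs in only one place, and no single structural change can yet be read from the data.

Compound 3 (`CC(C)n1cc(-c2ccnc3[nH]c(C4CCN(CC(=O)N5CCCCC5)CC4)cc23)ccc1=O`) is still unmeasured. It carries piperidin-1-yl in place of pyrrolidin-1-yl on a carbonyl carbon, and the rest of compound 1 is retained.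

Compound 2 at 7.6 differs from compound 1 at 7.8 in more than one place and still stays within the scatter, so no step beyond the scatter is expected in this assay for this smaller change. The estimated step is no change at the digits printed from compound 1 to compound 3 (within the scatter) and is expected to carry no clear direction. In this assay the estimate for compound 3 is 7.8 with a range of 7.5 to 8.1 expected around it.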

Compound 3, acid dissociation constant: 7.8
For compound 3 middle estimate and measured number coincide at the digits printed; the measured number falls inside the stated range.
By their numbers in this assay, from the lowest: compounds 2, 1 and 3 (each within the scatter of the next).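

In this assay, the series now has its first comparison that differs in one place, with piperidin-1-yl in place of pyrrolidin-1-yl on a carbonyl carbon: the step reads no change at the digits printed from compound 1 to compound 3 (within the scatter). At this position, whose carbonyl carbon also carries a saturated chain carbon, a six-membered non-aromatic ring with 6 heavy atoms can therefore replace a five-membered one with 5 heavy atoms without a step beyond the scatter in this read-out, which the two earlier compounds, differing in more than one place, could not show. No measured information accounts for this outcome.

Going by these compounds, this single step covers only an exchange between two saturated nitrogen rings of different size, so it remains open whether a morpholin-4-yl ring, an open-chain diethylamino group or a carboxylic acid on the same carbonyl carbon would also stay within the scatter. Compound 2 still differs from both compound 1 and compound 3 in more than one place, so the separate contribution of its dimethylamino group cannot be read from the compounds shown.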